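Furanylmethyl Thiocarbamate Variant Among Acyltransferase Inhibitors

The source may hold more compounds than are shown below. What is called first, only, known or untested is meant among the compounds shown, and "the series" means these compounds.

Compound 1 `CCCCCCOC(=O)NC(=O)Oc1c(C(C)C)cccc1C(C)C` — 53 nM
Compound 2 `CCCCC(C)(C)OC(=O)NC(=O)Oc1c(C(C)C)cccc1C(C)C` — 64 nM
Compound 3 `CC(C)c1cccc(C(C)C)c1OC(=O)NC(=O)SCc1ccc(Cl)cc1` — 160 nM

Of the compounds shown here, three sharing the same core have been measured in an assay on microsomes from intestine for inhibition of acyl-CoA:cholesterol acyltransferase (Oryctolagus cuniculus); on this read-out higher numbers stand for weaker inhibition and lower numbers for stronger inhibition. Compound 3 gives the highest number of the three: the step of a 3.0-fold higher number from compound 1 to compound 3 (0.48 log units; beyond the scatter) and the step of a 2.5-fold higher number from compound 2 to compound 3 (0.40 log units; beyond the scatter) are both beyond the scatter, while compound 1 and compound 2 sit within the scatter of each other, as a 1.2-fold higher number from compound 1 to compound 2 (0.08 log units; within the scatter) shows.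

Compound 4 `CC(C)c1cccc(C(C)C)c1OC(=O)NC(=O)SCc1ccco1` is the next member. It differs from compound 3 by furan-2-yl in place of 4-chlorophenyl on a saturated chain carbon bound to a sulfur. For the measured compounds named here, the measured steps that reach compound 3 all change the group on the carbonyl carbon, replacing an oxygen-linked chain with the (4-chlorobenzyl)sulfanyl group; none of them exchanges the aromatic ring within a sulfanyl series, so no measured step bears directly on this change. Without such a precedent in this assay, the expected step of a 1.4-fold higher number from compound 3 to compound 4 (0.14 log units; within the scatter) is small, with no direction that can be read from the data. In this assay compound 4 is therefore expected to give about 220 nM, within a range of 80 nM to 600 nM.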

Compound 4, half-maximal inhibitory concentration: 470 nM
The estimate for compound 4 lay 2.1-fold (0.33 log units) below the measured number; measured number inside the range.
By their numbers in this assay, from the lowest: compounds 1 and 2 (each within the scatter of the next); then compound 3; then compound 4.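

In this assay, for the compounds shown here, the ring on the saturated chain carbon bound to a sulfur proves not to be a silent part of the molecule: furan-2-yl in place of 4-chlorophenyl gives a 2.9-fold higher number from compound 3 to compound 4 (0.47 log units; beyond the scatter), whereas the earlier steps only exchanged the whole group on the carbonyl carbon. The same exchange widens the distance to the oxygen-linked chains, with a 7.3-fold higher number from compound 2 to compound 4 (0.87 log units; beyond the scatter) and an 8.9-fold higher number from compound 1 to compound 4 (0.95 log units; beyond the scatter), so that the ((furan-2-yl)methyl)sulfanyl group gives weaker inhibition than the three other groups on the carbonyl carbon. No measurement at hand accounts for this difference. The exchange removes the chlorine and changes the ring at once, so the compounds shown cannot separate the two. An unsubstituted phenyl or a thiophen-2-yl on that chain carbon would bear on this question.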